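This account rests on a few compounds, and the source may have more. Where it says the series, first, only, none or still open, it means among the compounds named here.

Compound 1 `Nc1cc(Cl)c2nc[nH]c2n1` and compound 2 `CC(=O)Nc1cc(Cl)c2nc[nH]c2n1` share one core and differ by hydrogen in place of acetyl on a nitrogen on an aromatic ring. In a functional assay on HEp-2 cells (Homo sapiens) for cytotoxicity (a lower number here means that less compound is needed, a higher number that more compound is needed for the effect), compound 1 gives 0.3 ug/mL. Compound 2 gives only a limit of the assay, > 22 ug/mL. The step of an at least 73-fold lower number from compound 2 to compound 1 (1.86 log units; beyond the scatter) therefore rests on (the limit of > 22 ug/mL in this assay, at which 2 of the 3 values shown sit). Compound 3 `CSc1cc(NC(C)=O)nc2[nH]cnc12` differs from compound 2 in its core by methylsulfanyl in place of chloro on an aromatic carbon. Compound 3 likewise gives only a limit, > 22 ug/mL. That leaves a step that the two limits leave unreadable from compound 2 to compound 3. Compound 4 `CSc1cc(N)nc2[nH]cnc12` has not yet been measured; it differs from compound 3 by hydrogen in place of acetyl on a nitrogen on an aromatic ring, the same change at the same place as between compound 2 and compound 1. Because an at least 73-fold lower number from compound 2 to compound 1 (1.86 log units; beyond the scatter) was large, a step of about an at least 22-fold lower number from compound 3 to compound 4 (1.34 log units; beyond the scatter) is expected, while the core change itself stays unread. Compound 4 is estimated at 1 ug/mL, between 0.1 ug/mL and 10 ug/mL.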

Compound 4, concentration for half-maximal effect: > 22 ug/mL
Compound 4: no number, only a limit (the forecaster's own chance of this, stated with the estimate: 25%); middle value at least 22-fold (1.34 log units) away from the limit.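

Carrying the change to the other core gives no readable result: in this assay compound 4 gives only a limit, > 22 ug/mL. Compound 3 also sits at a limit, so the steps between limits cannot be read, and the large drop seen on the core of compound 1 is neither confirmed nor ruled out on this core. The one readable comparison is an at least 73-fold higher number from compound 1 to compound 4 (1.86 log units; beyond the scatter), with methylsulfanyl in place of chloro on an aromatic carbon, and it too rests on a limit: the limit of > 22 ug/mL in this assay, at which 3 of the 4 values shown sit.

From the compounds shown here alone, it remains open whether a methoxy group or a dimethylamino group in place of chloro on that aromatic carbon would keep the low number of compound 1. Also open, going by these compounds, is what the true numbers of compound 2, compound 3 and compound 4 are.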